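The source may report more compounds than this note shows. Statements on the series, on what has been measured and on what is new or still open speak of the compounds shown alone.

In an ADME assay on HepG2 cells (Homo sapiens) for cytotoxicity, read by CellTiter-Glo, with a stated time of 72 h (on this read-out higher numbers stand for an effect only at larger amounts of compound and lower numbers for an effect already at smaller amounts), compound 1 (`C/C1=C/[C@]23O[C@H]2[C@H](C)C=C3C(=O)[C@@](C)(O)C(=O)CC(C)(C)/C=C/C1=O`) gives 26000 nM and compound 2 (`C/C1=C/C2=C[C@H](C)C[C@@]23O[C@]2(CC(C)(C)[C@@H](O)[C@@H]2C1=O)[C@@H](C)C3=O`) gives 26000 nM as well, so compound 2 stands level with compound 1 within the scatter. Compound 3 (`C/C1=C/C2=C[C@H](C)C[C@@]23O[C@]2(CC(C)(C)[C@@H](OC(C)C)[C@@H]2C1=O)[C@@H](C)C3=O`) differs from compound 2 by isopropyl in place of hydrogen on an oxygen on a saturated carbon as hydroxy to isopropoxy, with isopropyl in place of hydrogen on an oxygen on a saturated carbon. Among the compounds with values here, no measured step covers this change, so in this assay no step beyond the scatter is expected, with a slight lean to lower numbers. The estimated step of a 1.3-fold lower number from compound 2 to compound 3 (0.11 log units; within the scatter) is expected to stay small. For compound 3 the estimate is 20000 nM within an expected range of 8000 nM to 50000 nM on this read-out.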

Compound 3, half-maximal effective concentration: 26000 nM
For compound 3 the middle estimate is 1.3-fold (0.11 log units) below the measured one; low and high end bracket the measured number.
By their numbers in this assay, from the lowest: compounds 1, 2 and 3 (each within the scatter of the next).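

Hydroxy to isopropoxy, with isopropyl in place of hydrogen on an oxygen on a saturated carbon, gives no change at the digits printed from compound 2 to compound 3 (within the scatter) in this assay. Within the data shown here, this is the first reading at this position, and here the hydrogen on that oxygen can give way to isopropyl without a step beyond the scatter. No available data give a reason for this outcome.

On these data alone, whether this holds for a longer chain, an amine or a carboxylic acid at this oxygen stays open. A single change at one position also cannot show how far the position tolerates substitution in general.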